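Replacing 4-(trifluoromethyl)phenyl with 2,6-difluorophenyl in the series

A few compounds are considered here, and "the series" means these few. Any claim that something is new, unique, unknown or untested is made for them only; others in the source may bear on it.

In a functional assay on MCF7 cells (Homo sapiens) for inhibition, read by MTT assay (a higher number here means a weaker inhibitor, a lower number a stronger inhibitor), compound 1 `CCc1ccc(C(=O)Nc2ccc(Nc3ncnc4cc(OC)c(OC)cc34)cc2)cc1` gives 65000 nM and compound 2 `COc1cc2ncnc(Nc3ccc(NC(=O)c4ccccc4I)cc3)c2cc1OC` gives 37000 nM, which is a 1.8-fold lower number from compound 1 to compound 2 (0.24 log units; within the scatter). Compound 3 `COc1cc2ncnc(Nc3ccc(NC(=O)c4ccc(C(F)(F)F)cc4)cc3)c2cc1OC` reads > 100000 nM, and this is a limit of the assay, not a number. Compound 4 `COc1cc2ncnc(Nc3ccc(NC(=O)c4c(F)cccc4F)cc3)c2cc1OC` has 2,6-difluorophenyl in place of 4-(trifluoromethyl)phenyl on a carbonyl carbon. Two measured steps bring in the group that compound 4 gives up: an at least 2.7-fold higher number from compound 2 to compound 3 (0.43 log units; beyond the scatter) and an at least 1.5-fold higher number from compound 1 to compound 3 (0.18 log units; that floor lies within the scatter). Only the first of these lies beyond the scatter. Losing that group is therefore expected to move the number down, back toward the measured values, though the size remains uncertain. The expected step is an at least 1.8-fold lower number from compound 3 to compound 4 (0.25 log units; that floor lies within the scatter). For compound 4 the estimated value is 55000 nM, within an expected range of 20000 nM to 100000 nM.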

Compound 4, half-maximal inhibitory concentration: 24000 nM
Compound 4: middle estimate off by 2.3-fold (0.36 log units), on the high side, and the stated range covers the measured number.
By their numbers in this assay, from the lowest: compounds 4, 2 and 1 (each within the scatter of the next, the first and the last beyond it). At a limit, above all of these: compound 3.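

In this assay, moving from the 4-(trifluoromethyl)phenyl amide to the 2,6-difluorophenyl amide brings the series back to a measurable number, with an at least 4.1-fold lower number from compound 3 to compound 4 (0.61 log units; beyond the scatter) standing only as a floor. Compound 3 stands at a limit, not a number: the limit of > 100000 nM in this assay, at which 1 of the 4 values shown sits. Against the other amides the change reads a 1.5-fold lower number from compound 2 to compound 4 (0.19 log units; within the scatter) and a 2.7-fold lower number from compound 1 to compound 4 (0.43 log units; beyond the scatter), so at this position only the second of these separates compound 4 from another aryl amide with a measured number. On these data alone, whether an amine or a carboxylic acid on this phenyl would keep that number remains open, as does how far below these values any group on the carbonyl carbon can go.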